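The source may report more compounds than this note shows. Statements on the series, on what has been measured and on what is new or still open speak of the compounds shown alone.

Three members of the series have been measured in a functional assay on U-87MG ATCC cells (Homo sapiens) for inhibition, read by MTT assay, with a stated time of 72 h; on this read-out higher numbers stand for weaker inhibition and lower numbers for stronger inhibition. Compound 1 `COc1ccc(-n2nc(C(=O)Nc3ccc(Oc4ccnc5cc(OCCCN6CCCCC6)c(OC)cc45)c(F)c3)c(C)cc2=O)cc1` gives 1800 nM in this assay. Compound 2 `COc1ccc(-n2nc(C(=O)Nc3ccc(Oc4ccnc5cc(OCCCN6CCC(C)CC6)c(OC)cc45)c(F)c3)c(C)cc2=O)cc1` carries methyl in place of hydrogen on a saturated ring carbon and gives 2840 nM in this assay; the step is a 1.6-fold higher number from compound 1 to compound 2 (0.20 log units; within the scatter). Compound 3 `COc1cc2c(Oc3ccc(NC(=O)c4nn(-c5ccc(Cl)cc5)c(=O)cc4C)cc3F)ccnc2cc1OCCCN1CCCCC1` differs from compound 1 in its core by chloro in place of methoxy on an aromatic carbon. In this assay compound 3 gives 1400 nM; that step is a 1.3-fold lower number from compound 1 to compound 3 (0.11 log units; within the scatter). The numbers for compound 3 and compound 1 lie within the scatter of each other, while the gap between compound 3 and compound 2 lies beyond it.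

Compound 4 `COc1cc2c(Oc3ccc(NC(=O)c4nn(-c5ccc(Cl)cc5)c(=O)cc4C)cc3F)ccnc2cc1OCCCN1CCC(C)CC1` has not been measured. It differs from compound 3 by methyl in place of hydrogen on a saturated ring carbon, the same change as that between compound 1 and compound 2, and the place of the change reads identically in both pairs. Among the measured compounds shown here, the only guide is the measured step of a 1.6-fold higher number from compound 1 to compound 2 (0.20 log units; within the scatter), which was within the scatter. On that single pair compound 4 is expected to show a 1.6-fold higher number from compound 3 to compound 4 (0.20 log units; within the scatter). Compound 4 is accordingly estimated at 2200 nM in this assay, with a range from 1100 nM to 4500 nM.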

Compound 4, half-maximal inhibitory concentration: 1350 nM
Estimate against measurement, compound 4: 1.6-fold (0.21 log units) above, within the range that was stated.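

In this assay, methyl in place of hydrogen on the saturated ring carbon of compound 3 gives a 1.0-fold lower number from compound 3 to compound 4 (0.02 log units; within the scatter), and the two readings of this change do not differ beyond what two such steps allow: the same change on two cores in this assay, a 1.6-fold higher number (0.20 log units; within the scatter) from compound 1 to compound 2 and a 1.0-fold lower number (0.02 log units; within the scatter) from compound 3 to compound 4, 1.6-fold (0.21 log units) apart, within the scatter of two such steps

Chloro in place of methoxy on an aromatic carbon, read on the 4-methylpiperidin-1-yl compounds, gives a 2.1-fold lower number from compound 2 to compound 4 (0.32 log units; beyond the scatter), which lies beyond the scatter while its counterpart on the piperidin-1-yl compounds does not, yet this pair of steps also agrees within the scatter of two such steps: the same change on two cores in this assay, a 1.3-fold lower number (0.11 log units; within the scatter) from compound 1 to compound 3 and a 2.1-fold lower number (0.32 log units; beyond the scatter) from compound 2 to compound 4, 1.6-fold (0.21 log units) apart, within the scatter of two such steps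

Among the compounds shown here, both changes therefore carry between these two cores without a detectable difference, but each rests on only two small steps, so this does not show that either change would behave the same way on any further core.

The compounds shown leave open whether an ethyl or a hydroxyl group on that saturated ring carbon would follow the methyl step. They also leave open whether a fluoro or trifluoromethyl group in place of the chloro, or a dimethylamino group in place of the piperidin-1-yl, would carry across the cores in the same way.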